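Moving from a phenoxyacetyl to a propanoyl arm on compound 1

The compounds below may be only part of what the source reports. "The series", "measured", "known", "first", "only" and "open" are said of these compounds alone.

Compound 1 `CC(C)C[C@H](N)c1cc(C(F)(F)F)ccc1N1CCN(C(=O)COc2cccc(Cl)c2Cl)CC1` is measured in an assay on HEK293 cells for displacement of a labelled ligand from Melanocortin receptor 4 (Homo sapiens) (a higher number here means a weaker inhibitor, a lower number a stronger inhibitor), where compound 1 gives 2500 nM, the highest of the three numbers. Compound 2 `CC(C)C[C@H](N)c1ccccc1N1CCN(C(=O)[C@H](C)Cc2ccc(Cl)cc2F)CC1` gives 67 nM in this assay, and compound 3 `CC(C)C[C@H](N)c1ccccc1N1CCN(C(=O)[C@H](C)Cc2ccc(Cl)cc2Cl)CC1` gives 16 nM. The only single-point step among these three is a 4.2-fold lower number from compound 2 to compound 3 (0.62 log units; beyond the scatter).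

Compound 4 `CC(C)C[C@H](N)c1cc(C(F)(F)F)ccc1N1CCN(C(=O)[C@H](C)Cc2ccc(Cl)cc2)CC1` differs from compound 1 by 1-(4-chlorobenzyl)ethyl in place of (2,3-dichlorophenoxy)methyl on a carbonyl carbon. Within the data shown here, no measured step covers this exact change, so the expectation rests on the two values at hand: compound 2 and compound 3, which carry a 1-(benzyl)ethyl arm, sit well below compound 1, which carries the phenoxymethyl arm, though they also lack the trifluoromethyl on the core that compound 1 and compound 4 share. The step from compound 2 to compound 3 suggests that the benzyl substitution pattern matters, and compound 4 carries only a single chlorine there. Compound 4 is therefore expected to show a clearly lower number, roughly a 17-fold lower number from compound 1 to compound 4 (1.22 log units; beyond the scatter). The estimate for compound 4 in this assay is 150 nM, with a range from 40 nM to 600 nM.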

Compound 4, inhibition constant: 31 nM
Beside the measured number, compound 4's estimate is 4.8-fold (0.68 log units) above it, outside the stated range (below it).
By their numbers in this assay, from the lowest: compounds 3 and 4 (each within the scatter of the next); then compound 2; then compound 1.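

In this assay, the arm on the carbonyl carbon can now be read on its own, with the trifluoromethyl-bearing core held constant: there is an 81-fold lower number from compound 1 to compound 4 (1.91 log units; beyond the scatter). The two arms have the same count of heavy atoms, but the exchange changes several things at once, removing the ether oxygen, adding a defined stereocentre and altering the number and placing of the chlorines, so the step belongs to the arm as a whole and not to any one of these features. Nothing among the data shown explains the size of this step.

Which of these features carries the step remains open. A 1-(4-chlorophenoxy)ethyl arm on the same carbonyl carbon would test the ether oxygen apart from the other changes.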